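A Side-Chain Swap on a Core That Shows No Inhibition

The source may report more compounds than this note shows. Statements on the series, on what has been measured and on what is new or still open speak of the compounds shown alone.

Of the compounds shown here, two sharing one core have been tested in a functional assay (Homo sapiens) for inhibition; a higher number here means a weaker inhibitor, a lower number a stronger inhibitor. Compound 1 `CC(=O)OCCOn1cnc2c(S)nc(F)nc21` gives > 500000 nM, which is a limit of the assay and not a number. Compound 2 `CC(O)n1cnc2c(S)nc(F)nc21` likewise gives > 500000 nM in this assay, again a limit rather than a number. Within the data shown here, both results therefore sit at the same place, (the limit of > 500000 nM in this assay, at which 2 of the 2 values shown sit), so neither compound can be ranked against the other, and no step between measured compounds can be stated. Compound 3 `OCCOn1cnc2c(S)nc(F)nc21` has not yet been measured. It differs from compound 2 by 2-hydroxyethoxy in place of 1-hydroxyethyl on an aromatic nitrogen. Since compound 2 shows no measurable inhibition, the expected change in this assay from compound 2 to compound 3 is a number no higher from compound 2 to compound 3 (the limit leaves the size open), meaning no movement beyond the scatter. Compound 3 is thus estimated to give 500000 nM, within a range of 200000 nM to 2000000 nM, most likely again as a limit.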

Compound 3, half-maximal inhibitory concentration: > 500000 nM
Compound 3 ended at the assay's limit; the forecaster's own chance of this, stated with the estimate: 85%; the middle value lies on the limit itself.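

The steps from compound 2 to compound 3 and from compound 1 to compound 3 cannot be read, as all three compounds stop at one limit: the limit of > 500000 nM in this assay, at which 3 of the 3 values shown sit.

These compounds leave open whether any of them inhibits at all in this assay and whether the side chain on the shared core matters.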